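From a ring-free chain to a 3-(methylcarbamoyl)phenyl group

A few compounds are considered here, and "the series" means these few. Any claim that something is new, unique, unknown or untested is made for them only; others in the source may bear on it.

In a functional assay on EBC-1 cells (Homo sapiens) for antiproliferative activity, with a stated time of 72 h (a higher number here means a weaker inhibitor, a lower number a stronger inhibitor), the measured compounds give these values
- compound 1 `Cn1cc(-c2cc(F)c3ncc(Cc4ccc5ncccc5c4)n3c2)cn1`: 0.27 nM
- compound 2 `Fc1cc(F)cc(-c2cc(F)c3ncc(Cc4ccc5ncccc5c4)n3c2)c1`: 790 nM
- compound 3 `CCO/N=C(\C)c1cc(F)c2ncc(Cc3ccc4ncccc4c3)n2c1`: 1480 nM

These compounds share one core and differ only in the group on one aromatic carbon. Compound 3 belongs to the weak end of this small set, and the two numbers there lie close together (a 1.9-fold higher number from compound 2 to compound 3 (0.27 log units; within the scatter)). The gaps to the remaining compound are far larger (a 2900-fold higher number from compound 1 to compound 2 (3.47 log units; beyond the scatter); a 5500-fold higher number from compound 1 to compound 3 (3.74 log units; beyond the scatter)).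

Compound 4 `CNC(=O)c1cccc(-c2cc(F)c3ncc(Cc4ccc5ncccc5c4)n3c2)c1` keeps the core but carries a new group on that carbon (a group of 10 heavy atoms (8 carbon, 1 nitrogen, 1 oxygen; one six-membered aromatic ring of carbon only) in place of a group of 6 heavy atoms (4 carbon, 1 nitrogen, 1 oxygen; no ring), on an aromatic carbon). Its 3-(methylcarbamoyl)phenyl group contains a six-membered aromatic ring of carbon only. The group of compound 2 (790 nM) contains such a ring too, and that compound stays weak. Compound 1 (0.27 nM) shows that this carbon can also carry a group giving a far lower number. Within the data shown here, no measured compound tests the methylcarbamoyl part, so a moderate fall in the number is expected, with wide uncertainty (a 7.4-fold lower number from compound 3 to compound 4 (0.87 log units; beyond the scatter)). The estimated value for compound 4 is 200 nM in this assay and is expected to lie between 15 nM and 1500 nM as a range.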

Compound 4, half-maximal inhibitory concentration: 400 nM
For compound 4 the middle estimate is 2.0-fold (0.30 log units) below the measured one; low and high end bracket the measured number.
By their numbers in this assay, from the lowest: compound 1; then compounds 4, 2 and 3 (each within the scatter of the next, the first and the last beyond it).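

In this assay, the 3-(methylcarbamoyl)phenyl group does modestly better than the ring-free chain it replaces (a 3.7-fold lower number from compound 3 to compound 4 (0.57 log units; beyond the scatter)), so this carbon does respond to a change between these two groups, though only slightly. The methylcarbamoyl part now gets its first test against the 3,5-difluorophenyl group, and the two substituted phenyl groups cannot be told apart (a 2.0-fold lower number from compound 2 to compound 4 (0.30 log units; within the scatter)), so exchanging two fluoro groups for this amide gives no readable change at this position. The 1-methyl-1H-pyrazol-4-yl group remains far ahead of the new group (a 1500-fold higher number from compound 1 to compound 4 (3.17 log units; beyond the scatter)), which means that among these four compounds only that five-membered ring reaches the very low numbers.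

On these data alone, it remains open whether the methyl on that ring matters, and whether a pyrazol-4-yl group without the methyl or a pyridin-3-yl group would stay close to the pyrazole result or fall back among the weaker compounds. Nothing shown here explains why these groups differ so widely at this carbon.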